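Swapping a Five-Membered Ring on the Shared Core

The compounds below may be only part of what the source reports. "The series", "measured", "known", "first", "only" and "open" are said of these compounds alone.

Compound 1 `CCCNC(=O)c1ccc(Oc2nc(-c3c(C)noc3C)cnc2N)cc1` and compound 2 `Cc1noc(C)c1-c1cnc(N)c(Oc2ccc(C(=O)Nc3cc(Cl)ccn3)cc2)n1` share one core and differ only at an amide-type nitrogen. In a functional assay on HeLa cells (Homo sapiens) for inhibition, read by MTT assay, with a stated time of 72 h (on this read-out higher numbers stand for weaker inhibition and lower numbers for stronger inhibition), compound 1 gives 32100 nM, and compound 2 gives 37900 nM. The step of a 1.2-fold higher number from compound 1 to compound 2 (0.07 log units; within the scatter) lies within the scatter, so the two numbers are read as the same; compound 2 simply holds the higher of the two numbers, with compound 1 the nearest and within the scatter of it.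

Compound 3 `Cn1cc(-c2cnc(N)c(Oc3ccc(C(=O)Nc4cc(Cl)ccn4)cc3)n2)cn1` is not yet measured. It differs from compound 2 at an aromatic carbon of the core: 1-methyl-1H-pyrazol-4-yl in place of 3,5-dimethyl-1,2-oxazol-4-yl on an aromatic carbon. Within the data shown here, the only measured step, that from compound 1 to compound 2, concerns the amide-type nitrogen and not this aromatic carbon, so no measured step bears on the present change. With nothing to lean on, a 1.1-fold lower number from compound 2 to compound 3 (0.02 log units; within the scatter) is expected to stay within the scatter, in no particular direction. Compound 3 is therefore estimated at 36000 nM in this assay, with a range from 10000 nM to 130000 nM to reflect the lack of any guiding step.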

Compound 3, half-maximal inhibitory concentration: 40800 nM
The estimate for compound 3 lay 1.1-fold (0.05 log units) below the measured number; the measured number falls inside the stated range.
By their numbers in this assay, from the lowest: compounds 1, 2 and 3 (each within the scatter of the next).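

In this assay, among these compounds, the first look at this aromatic carbon of the shared core gives a 1.1-fold higher number from compound 2 to compound 3 (0.03 log units; within the scatter), so 1-methyl-1H-pyrazol-4-yl and 3,5-dimethyl-1,2-oxazol-4-yl cannot be told apart on this read-out. Together with the earlier step at the amide-type nitrogen, this means that a change at either of two separate places has so far left the number within the scatter, though each place has been tested by one swap only, and here both groups are five-membered aromatic rings with 2 hetero atoms and the same count of hydrogen-bond acceptors. No measurement is available that would explain why the two groups read alike.

From the compounds shown here alone, the swap stays within one narrow kind of group, so it remains open what a plain phenyl ring, a morpholine or a carboxylic acid on this aromatic carbon would give. It is also open whether 1-methyl-1H-pyrazol-4-yl would read the same with propyl on the amide-type nitrogen, as that pairing of the two places is not among the compounds shown here.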